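A few compounds are considered here, and "the series" means these few. Any claim that something is new, unique, unknown or untested is made for them only; others in the source may bear on it.

In a functional assay on K562 cells (Homo sapiens) for cytotoxicity, read by trypan blue exclusion, with a stated time of 96 h (a lower number here means a stronger inhibitor, a higher number a weaker inhibitor), compound 1 `COc1cc(OC)c(/C=C/S(=O)(=O)Cc2ccc(OC)c([N+](=O)[O-])c2)c(OC)c1` gives 2500 nM. Compound 2 `COC(=O)C(Nc1cc(CS(=O)(=O)/C=C/c2c(OC)cc(OC)cc2OC)ccc1OC)c1ccc(Br)cc1`, built on the same core, gives 200 nM. This is the lower of the two numbers, and so the stronger result, with a gap beyond the usual scatter of repeat measurements.

Compound 3 `COc1cc(OC)c(/C=C/S(=O)(=O)Cc2ccc(OC)c(NC(C(=O)O)c3ccc(F)cc3)c2)c(OC)c1` has not yet been measured. It departs from compound 2 in one place: carboxy(4-fluorophenyl)methyl in place of (4-bromophenyl)(methoxycarbonyl)methyl on a nitrogen on an aromatic ring. Put simply, carboxy(4-fluorophenyl)methyl stands in place of (4-bromophenyl)(methoxycarbonyl)methyl on a nitrogen on an aromatic ring. The rest of the molecule stays the same, and both groups hold one six-membered aromatic ring of carbon only.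

For the measured compounds named here, no measured pair shows what this swap does by itself, so the expectation starts from compound 2 at 200 nM. In this assay, no step beyond the scatter is expected, only a slight drift toward a weaker number, and the estimated change is a 1.5-fold higher number from compound 2 to compound 3 (0.18 log units; within the scatter). With just two measured values to lean on, the range has to stay wide. The estimated value for compound 3 is 300 nM, with an expected range of 60 nM to 1500 nM.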

Compound 3, half-maximal inhibitory concentration: 80 nM
Estimate against measurement, compound 3: 3.8-fold (0.57 log units) above; the measured number falls inside the stated range.
By their numbers in this assay, from the lowest: compound 3; then compound 2; then compound 1.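

The swap on the nitrogen brings a 2.5-fold lower number from compound 2 to compound 3 (0.40 log units; beyond the scatter) in this assay and shows that this group is still a place where the number can move, even after the large group of compound 2 is already there. Set against the nitro group of compound 1, the full (carboxy(4-fluorophenyl)methyl)amino group on that aromatic carbon brings a 31-fold lower number from compound 1 to compound 3 (1.49 log units; beyond the scatter) and leaves compound 3 with the lowest number of the three. Nothing available explains why either number moves.

The swap from compound 2 to compound 3 changes two things at once, methoxycarbonyl to carboxy and bromine to fluorine, so the compounds shown cannot tell which change goes with the lower number; a carboxy group paired with a 4-bromophenyl ring, or a methoxycarbonyl group paired with a 4-fluorophenyl ring, would separate the two. Also open, from the compounds shown here alone, is how a plain amine on that aromatic carbon, with nothing further on its nitrogen, would compare, and so how much of the large step belongs to the nitrogen itself and how much to the carboxy(4-fluorophenyl)methyl group it carries.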